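Swapping a cyanobenzyl for a cyclohexyl on the core

A few compounds are considered here, and "the series" means these few. Any claim that something is new, unique, unknown or untested is made for them only; others in the source may bear on it.

Of the compounds shown here, three of one series have been measured in an in vitro functional assay on cells for agonist activity at Bombesin receptor subtype-3 (Mus musculus), read by luminescence and calcium flux; a lower number here means that less compound is needed, a higher number that more compound is needed for the effect. Compound 1 `N#Cc1ccccc1Cc1cnc(CCc2ccc(-c3ccccc3C(=O)O)cc2)[nH]1` gives 642 nM in this assay. Compound 2 `CCCCc1cnc(C(CCC)Cc2ccc(-c3ccccc3C(=O)O)cc2)[nH]1` gives 165 nM, and compound 3 `CCCCc1cnc(/C=C/c2ccc(-c3ccccc3C(=O)O)cc2)[nH]1` gives 10000 nM. Among these three numbers, compound 1 holds the second highest: compound 2 sits lower and compound 3 sits higher, and both of those distances are beyond the usual scatter.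

The next compound, compound 4 `O=C(O)c1ccccc1-c1ccc(CCc2ncc(C3CCCCC3)[nH]2)cc1`, differs from compound 1 in a single place: cyclohexyl in place of 2-cyanobenzyl on an aromatic carbon. Within the data shown here, no pair of measured compounds shows this exact change, so its size is not known from the data. The closest hint is compound 2, which carries a plain alkyl group on the same part of the core and gives 165 nM, a lower number than compound 1, although compound 2 also differs elsewhere. On that basis, a modest step is expected, towards a lower number but possibly within the scatter, as a 1.8-fold lower number from compound 1 to compound 4 (0.26 log units; within the scatter). Compound 4 is therefore estimated at 350 nM in this assay, within a range from 90 nM to 1400 nM.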

Compound 4, half-maximal effective concentration: 14.7 nM
Compound 4: the middle estimate sits 24-fold (1.38 log units) above what was measured; measured number below the stated range.
By their numbers in this assay, from the lowest: compound 4; then compound 2; then compound 1; then compound 3.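

In this assay, among these compounds, the group on this aromatic carbon proves to matter a great deal: putting cyclohexyl in place of 2-cyanobenzyl brings a 44-fold lower number from compound 1 to compound 4 (1.64 log units; beyond the scatter) and so moves the series to its lowest number so far. Among the compounds shown here, no earlier pair differed at this position alone, so this is the first direct reading of it, and it shows that neither the aromatic ring nor the nitrile of 2-cyanobenzyl is needed for a low number. Nothing at hand explains why the step is so large.

Going by these compounds, whether a plain benzyl or phenyl group here would land nearer to cyclohexyl or to 2-cyanobenzyl remains open, as does the effect of a smaller cyclopentyl or a larger cycloheptyl ring. Also open, on these data alone, is how a hydroxyl or an amine on the cyclohexyl ring would shift the number.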